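Diethylamino Gives Way to Piperidin-1-yl

The source may report more compounds than this note shows. Statements on the series, on what has been measured and on what is new or still open speak of the compounds shown alone.

Compound 1 `CCn1c(N)c(-c2nc3ccccc3[nH]2)c2nc(C#N)c(C#N)nc21` and compound 2 `CCN(CC)CCCn1c(N)c(-c2nc3ccccc3[nH]2)c2nc(C#N)c(C#N)nc21` share one core and differ in the chain on an aromatic nitrogen. In an ADME assay on HEK293 cells (Homo sapiens) for cytotoxicity, read by MTT assay, with a stated time of 48 h (on this read-out higher numbers stand for weaker inhibition and lower numbers for stronger inhibition), compound 1 gives > 50000 nM, which is a limit of the assay and not a number. Among the compounds with values here, compound 2 gives 7870 nM, the only actual number so far, so it has no measured neighbour to be ranked against.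

Compound 3 `N#Cc1nc2c(-c3nc4ccccc4[nH]3)c(N)n(CCCN3CCCCC3)c2nc1C#N` keeps the chain of compound 2 and changes only the group carried on it: piperidin-1-yl in place of diethylamino on a saturated chain carbon, three bonds along the chain from an aromatic nitrogen. Just one measured step bears on this, and only loosely. That step, an at least 6.3-fold lower number from compound 1 to compound 2 (0.80 log units; beyond the scatter), lies beyond the scatter, but it put diethylamino on the chain where none existed. The new change does not remove such a group; it exchanges it for piperidin-1-yl. Within the data shown here, no measured pair shows such an exchange, so no direction can be argued from the data. The expected result is no shift beyond the scatter in this assay, an estimated 1.0-fold lower number from compound 2 to compound 3 (0.02 log units; within the scatter). Compound 3 is estimated at 7500 nM, with an expected range from 3000 nM to 20000 nM.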

Compound 3, half-maximal inhibitory concentration: 6720 nM
Compound 3: middle estimate off by 1.1-fold (0.05 log units), on the high side; the range from low to high includes it.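

In this assay, replacing the open-chain diethylamino with piperidin-1-yl, which ties the same kind of amine into a six-membered non-aromatic ring, gives a 1.2-fold lower number from compound 2 to compound 3 (0.07 log units; within the scatter), so at this position, on a saturated chain carbon three bonds along the chain from an aromatic nitrogen, the exchange makes no measurable difference. Compound 2 alone could not show whether the step away from compound 1 needed diethylamino in particular, but a second amine at the end of the chain now gives an at least 7.4-fold lower number from compound 1 to compound 3 (0.87 log units; beyond the scatter), so among the compounds shown that step does not depend on this one group. The full size of both steps from compound 1 stays unknown because the value of compound 1 is a limit and not a number: the limit of > 50000 nM in this assay, at which 1 of the 3 values shown sits.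

The compounds shown do not separate the effect of the longer 3-carbon chain from that of the amine at its end, which a plain propyl group on the same nitrogen would address. On these data alone, how a morpholin-4-yl group, a primary amine or a carboxylic acid at the end of that chain would read also remains open.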